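The compounds below may be only part of what the source reports. "The series", "measured", "known", "first", "only" and "open" are said of these compounds alone.

Measured so far, in an assay on isolated protein for binding affinity to melatonin receptor type 1A (Homo sapiens); on this read-out lower numbers stand for stronger inhibition and higher numbers for weaker inhibition:

compound 1 `COc1cccc(Oc2ccc(NC(C)=O)cc2)c1` — 84 nM
compound 2 `COc1cccc(Oc2ccc(NC(=O)C3CC3)cc2)c1` — 99 nM

Going by the values given here, compound 2 has the higher of the two numbers, but its only neighbour is compound 1, and the step of a 1.2-fold higher number from compound 1 to compound 2 (0.07 log units; within the scatter) lies within the scatter of repeated measurements. On the numbers shown, compound 1 and compound 2 are therefore indistinguishable in this assay.

Compound 3 `C/C=C/C(=O)Nc1ccc(Oc2cccc(OC)c2)cc1` has not yet been measured. It differs from compound 2 in one place: prop-1-en-1-yl in place of cyclopropyl on a carbonyl carbon. Both substituents are small groups of three carbons attached to the carbonyl carbon of the amide, so the change is a swap of one small group for another at the same spot.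

Among the compounds with values here, only one measured step bears on this position, the exchange of methyl for cyclopropyl from compound 1 to compound 2, and that step a 1.2-fold higher number from compound 1 to compound 2 (0.07 log units; within the scatter) was within the scatter. Nothing in the data points to this position driving large changes in this assay. The expectation is therefore a step of about a 1.0-fold higher number from compound 2 to compound 3 (0.00 log units; within the scatter), that is, no change beyond the scatter. Compound 3 is estimated at 100 nM, with a range from 40 nM to 250 nM.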

Compound 3, inhibition constant: 98 nM
Estimate against measurement, compound 3: 1.0-fold (0.01 log units) above; measured number inside the range.
By their numbers in this assay, from the lowest: compounds 1, 3 and 2 (each within the scatter of the next).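

In this assay, replacing the three-membered ring of cyclopropyl with prop-1-en-1-yl, which has no ring and one double bond, gives a 1.0-fold lower number from compound 2 to compound 3 (0.00 log units; within the scatter), so a ring on this carbonyl carbon is not required to keep the number within the scatter. Putting the same prop-1-en-1-yl in place of methyl gives a 1.2-fold higher number from compound 1 to compound 3 (0.07 log units; within the scatter), so three different small carbon groups at this place now read alike, whereas the earlier pair included no group with a double bond. No further measurement accompanies these numbers to say why the three groups read alike.

On these data alone, all three groups are small and contain only carbon and hydrogen, so it remains open whether the number would hold with a longer chain such as hexyl, with a phenyl ring, or with a group carrying an amine or a carboxylic acid. As far as these compounds go, the rest of the core stays the same in all three compounds, so how strongly changes elsewhere, such as to the methoxy group, would move the number also remains unknown.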